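This account rests on a few compounds, and the source may have more. Where it says the series, first, only, none or still open, it means among the compounds named here.

Measured so far:

compound 1, `CCCCc1ccc(-c2cc(OC)cc(C(=O)Nc3nn[nH]n3)n2)cc1`, 29%
compound 2, `COc1ccc(-c2cccc(C(=O)Nc3nn[nH]n3)n2)cc1`, 12%
compound 3, `CCc1ccc(-c2cccc(C(=O)Nc3nn[nH]n3)n2)cc1`, 39%

In a functional assay on the whole organism for inhibition, with Rattus norvegicus as the target, at a dose of 1 mg/kg by the oral route (on this read-out lower numbers stand for a weaker effect and higher numbers for a stronger effect at the one dose given), compound 2 gives 12%, and compound 3 gives 39%. Going by the values given here, the one change between them is ethyl in place of methoxy on an aromatic carbon, and it made a step of a number 27 percentage points higher from compound 2 to compound 3 (beyond the scatter). Compound 1 gives 29% in this assay; the difference between its core and that of compound 2 is not broken down here. Set beside compound 3, the value of compound 1 is within the scatter, while against compound 2 it is beyond the scatter.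

Compound 4 is `CCCCc1ccc(-c2cc(CC)cc(C(=O)Nc3nn[nH]n3)n2)cc1`, not yet measured. It differs from compound 1 by ethyl in place of methoxy on an aromatic carbon. Among the compounds with values here, this is the same kind of change as the one from compound 2 to compound 3, but not the same: there the place was on a six-membered aromatic ring of carbon only, para to a large group, whereas here it is on a six-membered aromatic ring with one nitrogen, meta to a (2H-tetrazol-5-yl)carbamoyl group, meta to a large group, opposite the ring nitrogen. Because the comparable change gave a number 27 percentage points higher from compound 2 to compound 3 (beyond the scatter), a rise is expected for compound 4, though tempered for the different place, amounting to an estimated a number 16 percentage points higher from compound 1 to compound 4 (beyond the scatter). Compound 4 is therefore expected to give about 45% in this assay, with an estimated range from 25% to 65%.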

Compound 4, a percentage reported as inhibition, in the whole organism at one dose (the size of the read-out at that dose, not a potency): 20%
The estimate for compound 4 lay 25 percentage points above the measured number; measured number outside the range, below it.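

On the core of compound 1, the swap of methoxy for ethyl on an aromatic carbon gave a step in this assay of a number 9 percentage points lower from compound 1 to compound 4 (within the scatter) and so did not repeat the rise seen on the other core. The same change therefore does not carry over with one size from core to core in this series, as the two steps differ: the same change on two cores in this assay, a number 27 percentage points higher (beyond the scatter) from compound 2 to compound 3 and a number 9 percentage points lower (within the scatter) from compound 1 to compound 4, 36 percentage points apart, beyond the scatter of two such steps. This does not show why they differ, since the two cores are not the same and the change stands at a different place on each, and a single pair on each core cannot separate these two things or show how the change would behave on any further core.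

Only methoxy and ethyl appear at these places, so the compounds shown leave open what an amine, a carboxylic acid or a longer chain would do there. They also leave open how the two cores would compare with the same group at the same place, and the read-out at one dose says nothing about potency.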